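A few compounds are considered here, and "the series" means these few. Any claim that something is new, unique, unknown or untested is made for them only; others in the source may bear on it.

In an assay on isolated protein for inhibition of Fatty-acid amide hydrolase 1 (Homo sapiens) (on this read-out lower numbers stand for stronger inhibition and higher numbers for weaker inhibition), compound 1 `O=C(CCCC1CCN(Cc2ccccc2)CC1)c1ncco1` gives 315 nM, compound 2 `COc1cccc(CN2CCC(CCCC(=O)c3ncco3)CC2)c1` gives 34 nM and compound 3 `O=C(CCCC1CCN(Cc2ccccc2Cl)CC1)c1ncco1` gives 260 nM. Compound 3 thus sits second highest of the three; its nearest value is shown by a 1.2-fold lower number from compound 1 to compound 3 (0.08 log units; within the scatter), its furthest by a 7.6-fold higher number from compound 2 to compound 3 (0.88 log units; beyond the scatter). Compound 4 `O=C(CCCC1CCN(Cc2ccc(Cl)cc2)CC1)c1ncco1` differs from compound 3 by 4-chlorophenyl in place of 2-chlorophenyl on a saturated chain carbon bound to an amine nitrogen in a ring. Within the data shown here, the steps that bear on it are a 1.2-fold lower number from compound 1 to compound 3 (0.08 log units; within the scatter), which shows the chloro as such changing little, and a 9.3-fold lower number from compound 1 to compound 2 (0.97 log units; beyond the scatter), which shows that a change of the group at this place can lower the number substantially; no measured step carries a 4-chlorophenyl. A modest shift in this assay is expected, a 1.3-fold lower number from compound 3 to compound 4 (0.11 log units; within the scatter), with wide uncertainty. Compound 4 is therefore estimated at 200 nM, range 60 nM to 600 nM.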

Compound 4, half-maximal inhibitory concentration: 66 nM
The estimate for compound 4 lay 3.0-fold (0.48 log units) above the measured number; measured number inside the range.
By their numbers in this assay, from the lowest: compounds 2 and 4 (each within the scatter of the next); then compounds 3 and 1 (each within the scatter of the next).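

The move from 2-chlorophenyl to 4-chlorophenyl gives a 3.9-fold lower number from compound 3 to compound 4 (0.60 log units; beyond the scatter) with the same atoms joined differently, so at this position where the chloro stands matters, not only its presence. Chloro in place of hydrogen gives a 4.8-fold lower number from compound 1 to compound 4 (0.68 log units; beyond the scatter) in this arrangement, unlike the small step to compound 3. 4-Chlorophenyl in place of 3-methoxyphenyl gives a 1.9-fold higher number from compound 2 to compound 4 (0.29 log units; within the scatter) and leaves the two groups unseparated in this assay here. No evidence is at hand on the origin of these differences.
Open, as far as these compounds go, is whether a nitrile or trifluoromethyl group in place of the chloro of compound 4 would hold this level.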